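A few compounds are considered here, and "the series" means these few. Any claim that something is new, unique, unknown or untested is made for them only; others in the source may bear on it.

Compound 1 `COc1cccc(/C=C/C(=O)c2sc(Nc3ccccc3)nc2C)c1`: in a functional assay on NCI-H460 cells (Homo sapiens) for cytotoxicity, read by MTT assay (a higher number here means a weaker inhibitor, a lower number a stronger inhibitor), compound 1 reaches only the limit > 25000 nM.
Compound 2 `Cc1nc(Nc2ccccc2)sc1C(=O)/C=C/c1ccc(Cl)cc1`: in this assay compound 2 reaches only the limit > 25000 nM.

The step that the two limits leave unreadable from compound 1 to compound 2 cannot be read, since both values sit at the limit of > 25000 nM in this assay, at which 2 of the 2 values shown sit. Compound 2 therefore stands at a limit, not at a number. Compound 3 `Cc1ccccc1Nc1nc(C)c(C(=O)/C=C/c2ccc(Cl)cc2)s1` differs from compound 2 by methyl in place of hydrogen on an aromatic carbon. Going by the values given here, no measured step bears on this change, and no direction can be read from the data. Compound 3 is expected to give a step that the limit leaves unreadable from compound 2 to compound 3. For compound 3 the estimated value in this assay is 30000 nM, with a range from 8000 nM to 100000 nM.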

Compound 3, half-maximal inhibitory concentration: > 25000 nM
Compound 3 ended at the assay's limit; the forecaster's own chance of this, stated with the estimate: 80%; the middle value is on the limit's open side.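

Compound 3, like compound 2, stands only at a limit, so no new step can be read between them: the limit of > 25000 nM in this assay, at which 3 of the 3 values shown sit. The compounds shown leave open how far each lies past that limit, and whether methyl in place of hydrogen changes anything.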